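Trifluoromethyl for methyl on the core: compound 4

The source may report more compounds than this note shows. Statements on the series, on what has been measured and on what is new or still open speak of the compounds shown alone.

Of the compounds shown here, three have been measured in a functional assay on MCF7 cells (Homo sapiens) for inhibition, read by MTT assay, with a stated time of 72 h; on this read-out higher numbers stand for weaker inhibition and lower numbers for stronger inhibition. Compound 1 `CN(C(=O)NC(=O)c1cccc(C(F)(F)F)c1)c1nc(C(F)(F)F)c(C(=O)N/N=C/c2ccccc2C(F)(F)F)s1` gives 7.69 ug/mL. Among the measured compounds shown here, compound 2 `CN(C(=O)NC(=O)c1ccc(Cl)cc1Cl)c1nc(C(F)(F)F)c(C(=O)N/N=C/c2ccccc2C(F)(F)F)s1` gives 9.12 ug/mL; the only one-point step measured, a 1.2-fold higher number from compound 1 to compound 2 (0.07 log units; within the scatter), stays within the scatter. Compound 3 `Cc1nc(N(C)C(=O)NC(=O)c2c(F)cccc2F)sc1C(=O)N/N=C/c1ccccc1C(F)(F)F` gives 7.34 ug/mL; its number sits within the scatter of compound 1 and of compound 2, so the three cannot be told apart on this assay.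

Compound 4 `CN(C(=O)NC(=O)c1c(F)cccc1F)c1nc(C(F)(F)F)c(C(=O)N/N=C/c2ccccc2C(F)(F)F)s1` differs from compound 3 in one place: trifluoromethyl in place of methyl on an aromatic carbon. This is the group that compound 1 and compound 2 already carry on the shared core, while their acyl aryl groups differ from that of compound 3. For the measured compounds named here, no measured step bears directly on this change; the step of a 1.2-fold higher number from compound 1 to compound 2 (0.07 log units; within the scatter) concerns a different part of the molecule. What the numbers show is that compound 1, compound 2 and compound 3 all lie within the scatter of each other, whether the core bears methyl or trifluoromethyl.

Compound 4 is therefore expected to show no step beyond the scatter, a 1.0-fold higher number from compound 3 to compound 4 (0.02 log units; within the scatter), in this assay. The estimate for compound 4 is 7.6 ug/mL, with a range from 3.8 ug/mL to 15 ug/mL.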

Compound 4, half-maximal inhibitory concentration: 20.4 ug/mL
The estimate for compound 4 lay 2.7-fold (0.43 log units) below the measured number, outside the stated range (above it).
By their numbers in this assay, from the lowest: compounds 3, 1 and 2 (each within the scatter of the next); then compound 4.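

In this assay this position on the shared core matters when 2,6-difluorophenyl sits on the carbonyl carbon: a 2.8-fold higher number from compound 3 to compound 4 (0.44 log units; beyond the scatter) goes with trifluoromethyl in place of methyl. With trifluoromethyl on the core, the aryl group on the carbonyl carbon also moves the number: a 2.2-fold higher number from compound 2 to compound 4 (0.35 log units; beyond the scatter) goes with 2,6-difluorophenyl in place of 2,4-dichlorophenyl and a 2.7-fold higher number from compound 1 to compound 4 (0.42 log units; beyond the scatter) goes with 2,6-difluorophenyl in place of 3-(trifluoromethyl)phenyl, while a 1.2-fold higher number from compound 1 to compound 2 (0.07 log units; within the scatter) stays within the scatter. No data at hand give a reason for these steps.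

Open, on these data alone, is whether trifluoromethyl in place of methyl gives a step of the same size with 2,4-dichlorophenyl or 3-(trifluoromethyl)phenyl on the carbonyl carbon. Also open, as far as these compounds go, is how an ethyl group or a primary amine at this aromatic carbon would read in this assay on the shared core.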